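A few compounds are considered here, and "the series" means these few. Any claim that something is new, unique, unknown or untested is made for them only; others in the source may bear on it.

Measured in a functional assay on HeLa cells (Homo sapiens) for inhibition; on this read-out lower numbers stand for stronger inhibition and higher numbers for weaker inhibition:
- Compound 1 `COc1cc(/C=C/c2cn(C(C)=O)c3ccccc23)cc(OC)c1OC`: > 5000 nM (a limit)
- Compound 2 `COc1cc(/C=C\c2cn(C(C)=O)c3ccccc23)cc(OC)c1OC`: 2850 nM
- Compound 3 `COc1cc(/C=C\c2ccc3c(ccn3S(=O)(=O)c3ccccc3)c2)cc(OC)c1OC`: > 5000 nM (a limit)

Compound 3 has no number, only a limit of > 5000 nM. Compound 4 `COc1cc(/C=C\c2ccc3[nH]ccc3c2)cc(OC)c1OC` differs from it by hydrogen in place of phenylsulfonyl on an aromatic nitrogen. Going by the values given here, the only measured step, an at least 1.7-fold lower number from compound 1 to compound 2 (0.24 log units; that floor lies within the scatter), concerns (the fact that compounds 1 and 2 differ only in the configuration as drawn), so it gives no size for this change. The data offer only weak guidance, but a number is expected for compound 4, resting on compound 2 at 2850 nM, the Z compound that gave one. The estimated outcome is an at least 3.3-fold lower number from compound 3 to compound 4 (0.52 log units; beyond the scatter), a move towards stronger inhibition of uncertain size. Compound 4 is estimated at 1500 nM, with an expected range of 200 nM to 6000 nM.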

Compound 4, half-maximal inhibitory concentration: 34 nM
The estimate for compound 4 lay 44-fold (1.64 log units) above the measured number; measured number outside the range, below it.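

In this assay, the aromatic nitrogen of the five-membered ring proves to be a position with a large effect: hydrogen in place of phenylsulfonyl gives an at least 140-fold lower number from compound 3 to compound 4 (2.16 log units; beyond the scatter). The only earlier step concerned configuration, so this is the first size shown for a change of substituent at this nitrogen. Compound 3 stands at a limit, so this step is only a floor: the limit of > 5000 nM in this assay, at which 2 of the 4 values shown sit.

As far as these compounds go, it remains open whether the nitrogen needs its hydrogen or only the phenylsulfonyl is poorly accepted. Compounds carrying methyl or benzyl on this nitrogen would separate these two readings.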